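The compounds below may be only part of what the source reports. "The series", "measured", "known", "first", "only" and "open" are said of these compounds alone.

Measured in a functional assay on HeLa cells (Homo sapiens) for inhibition, read by cell counting, with a stated time of 4 days; a lower number here means a stronger inhibitor, a higher number a weaker inhibitor:
Compound 1 `C=C(Br)C(=O)Nc1cccc(-c2cn3nc(Cc4cccc(OC)c4)sc3n2)c1`: 2500 nM
Compound 2 `COc1ccc(-c2nn3cc(-c4cccc(N)c4)nc3s2)cc1OC`: 26000 nM

Of these two numbers, compound 2 has the higher one, so it is the weaker inhibitor of the pair; the number for compound 1 is lower, and the gap between the two is wider than the usual scatter of repeated measurements. The two compounds differ in more than one place, so their values alone do not show which difference matters.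

Compound 3 `C=C(Br)C(=O)Nc1cccc(-c2cn3nc(-c4ccc(OC)c(OC)c4)sc3n2)c1` is built from compound 2 by a single change: (1-bromoethenyl)carbonyl in place of hydrogen on a nitrogen on an aromatic ring. Compound 1 also carries a (1-bromoethenyl)carbonyl group on a nitrogen on an aromatic ring, though with another group on the shared core, and in this assay compound 1 gives 2500 nM. Compound 3 is therefore expected to be a stronger inhibitor, with an estimated step of a 7.4-fold lower number from compound 2 to compound 3 (0.87 log units; beyond the scatter). The estimate for compound 3 in this assay is 3500 nM, between 900 nM and 14000 nM.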

Compound 3, half-maximal inhibitory concentration: 610 nM
Estimate against measurement, compound 3: 5.7-fold (0.76 log units) above; the whole stated range lies above it.
By their numbers in this assay, from the lowest: compound 3; then compound 1; then compound 2.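

In this assay, the change from amino to ((1-bromoethenyl)carbonyl)amino can now be read on its own: (1-bromoethenyl)carbonyl in place of hydrogen on a nitrogen on an aromatic ring gives a 43-fold lower number from compound 2 to compound 3 (1.63 log units; beyond the scatter), a large step. With that group kept, the other place on the shared core also counts, since 3,4-dimethoxyphenyl in place of 3-methoxybenzyl on an aromatic carbon gives a 4.1-fold lower number from compound 1 to compound 3 (0.61 log units; beyond the scatter), a modest step. Nothing available explains why either change lowers the number.

The compounds shown do not tell whether the bromine is needed, since an acetyl group or a propenoyl group without bromine on the same nitrogen could give a different number. As far as these compounds go, it also remains open how a single methoxy group or a hydroxyl group on the phenyl ring would compare.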